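The compounds below may be only part of what the source reports. "The series", "measured", "known", "first", "only" and "open" are said of these compounds alone.

Values so far in a toxicity assay on Vero C1008 cells (Chlorocebus sabaeus) for cytotoxicity, read by MTT assay, with a stated time of 48 h; a lower number here means that less compound is tolerated, a higher number that more compound is tolerated
- compound 1 `O=C(Nc1cccc([N+](=O)[O-])c1)c1cc(Cl)ccc1O` gives 3530 nM
- compound 2 `O=C(Nc1cccc(Cl)c1)c1cc(Cl)ccc1O` gives 2460 nM
- compound 3 `O=C(Nc1ccc(F)c(Cl)c1)c1cc(Cl)ccc1O` gives 2440 nM

Compound 2 with 2460 nM stands within the scatter of compound 1 and of compound 3, so the three numbers offer no ranking around it. Still to be measured is compound 4 `O=C(Nc1cccc(F)c1)c1cc(Cl)ccc1O` and its difference from compound 2 is fluoro in place of chloro on an aromatic carbon (fluoro in place of chloro on an aromatic carbon, meta to a large group).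

Within the data shown here, two measured steps bear on this change. Chloro in place of nitro on an aromatic carbon gave a 1.4-fold lower number from compound 1 to compound 2 (0.16 log units; within the scatter) and fluoro in place of hydrogen on an aromatic carbon gave a 1.0-fold lower number from compound 2 to compound 3 (0.00 log units; within the scatter) as the second case. Neither step leaves the scatter. Among the measured compounds shown here, no measured pair shows this exact exchange, so the expectation rests on these two small steps alone. No step beyond the scatter is therefore expected in this assay and no direction is favoured. The expected change is a 1.1-fold higher number from compound 2 to compound 4 (0.02 log units; within the scatter) and would be read as no real shift. For compound 4 the estimated value is 2600 nM with an expected range from 1500 nM to 4500 nM in this series.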

Compound 4, half-maximal cytotoxic concentration: 3630 nM
Compound 4: middle estimate off by 1.4-fold (0.14 log units), on the low side; low and high end bracket the measured number.
By their numbers in this assay, from the lowest: compounds 3, 2, 1 and 4 (each within the scatter of the next).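

In this assay, among these compounds, the exchange of chloro for fluoro on an aromatic carbon, meta to a large group, now has its own measured pair, and a 1.5-fold higher number from compound 2 to compound 4 (0.17 log units; within the scatter) stays within the scatter, so the earlier steps no longer have to stand in for this change. The series also gains a direct comparison of fluoro with nitro at this place, where a 1.0-fold higher number from compound 1 to compound 4 (0.01 log units; within the scatter) likewise stays within the scatter, and chloro, fluoro and nitro can therefore not be ranked here on these numbers. Nothing available explains the flat response at this position, which remains an observation on compounds 1, 2 and 4 only.

The compounds shown leave open whether an amine, a carboxylic acid or a longer chain at this place would give a step beyond the scatter, as every group seen here leaves the number within it. They also leave open whether the same exchange behaves alike with other changes to the shared core, since the only variation shown lies on the ring carrying these groups.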